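Isopropyl added to the phenyl of compound 2

The source may report more compounds than this note shows. Statements on the series, on what has been measured and on what is new or still open speak of the compounds shown alone.

Compound 1 `N#Cc1c(Nc2ccc(F)cc2)nc(SCc2cn(Cc3ccccc3Cl)nn2)nc1-c1ccccc1` gives 8740 nM in a functional assay on MGC-803 cells (Homo sapiens) for inhibition, read by MTT assay, with a stated time of 72 h; on this read-out higher numbers stand for weaker inhibition and lower numbers for stronger inhibition. Compound 2 `Cc1ccc(Nc2nc(SCc3cn(Cc4ccccc4Cl)nn3)nc(-c3ccccc3)c2C#N)cc1` gives 7190 nM in this assay; the step of a 1.2-fold lower number from compound 1 to compound 2 (0.08 log units; within the scatter) lies within the scatter. Compound 3 `Cc1ccc(Nc2nc(SCc3cn(Cc4ccccc4Cl)nn3)nc(-c3ccc(C(C)C)cc3)c2C#N)cc1` carries the change (isopropyl in place of hydrogen on an aromatic carbon). Among the compounds with values here, no measured step touches this phenyl: the only step in hand, a 1.2-fold lower number from compound 1 to compound 2 (0.08 log units; within the scatter), sits on the other aryl ring and is within the scatter, so it gives neither direction nor size. For compound 3 the expected step is a 1.1-fold lower number from compound 2 to compound 3 (0.04 log units; within the scatter), nothing beyond the scatter, held with a wide range. Compound 3 is estimated at 6500 nM, between 2200 nM and 19000 nM.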

Compound 3, half-maximal inhibitory concentration: > 64000 nM
Compound 3 gave a limit, no number; the forecaster's own chance of this, stated with the estimate: 10%; at least 9.8-fold (0.99 log units) between middle value and limit.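

In this assay, within the data shown here, the change from phenyl to 4-isopropylphenyl brings an at least 8.9-fold higher number from compound 2 to compound 3 (0.94 log units; beyond the scatter), so this phenyl responds to substitution with weaker inhibition, whereas the one earlier step, a 1.2-fold lower number from compound 1 to compound 2 (0.08 log units; within the scatter), sits on the other aryl ring and is within the scatter. The reading for compound 3 is a limit and not a number, so the step has a lower bound only: the limit of > 64000 nM in this assay, at which 1 of the 3 values shown sits.

From the compounds shown here alone, whether any group on this aromatic carbon gives the same loss, or only one of isopropyl's size, stays open. A methyl, a methoxy or an amine at the same place would separate these cases.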